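The compounds below may be only part of what the source reports. "The series", "measured", "known", "first", "only" and "open" are said of these compounds alone.

Of the compounds shown here, three built on the same core have been measured in a functional assay on the whole organism with Mus musculus as the target, in the writhing test, at a dose of 0.04 mmol/kg by the subcutaneous route; on this read-out lower numbers stand for less inhibition and higher numbers for more inhibition at the one dose given (going by the name of the read-out). Compound 1 `CCCNC(=O)OC(CC1CC[N+]2(CCCC2)CC1)CC1CC[N+]2(CCCC2)CC1` gives 70.9% in this assay. Compound 2 `CCCCCNC(=O)OC(CC1CC[N+]2(CCCC2)CC1)CC1CC[N+]2(CCCC2)CC1` gives 75.2% in this assay. Compound 3 `CCCCCCCCNC(=O)OC(CC1CC[N+]2(CCCC2)CC1)CC1CC[N+]2(CCCC2)CC1` gives 36.4% in this assay, the lowest of the three numbers, with both other compounds beyond the scatter above it. The step of a number 4.3 percentage points higher from compound 1 to compound 2 (within the scatter) lies within the scatter, whereas a number 34.5 percentage points lower from compound 1 to compound 3 (beyond the scatter) and a number 38.8 percentage points lower from compound 2 to compound 3 (beyond the scatter) were both large losses of inhibition as the chain on the amide-type nitrogen grew longer.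

Compound 4 `CCCCCCCCCCCNC(=O)OC(CC1CC[N+]2(CCCC2)CC1)CC1CC[N+]2(CCCC2)CC1` has not yet been measured. Its difference from compound 3 is this:

propyl in place of hydrogen on a saturated chain carbon, eight bonds along the chain from an amide-type nitrogen

Going by the values given here, this carries the chain on the amide-type nitrogen further along the same line that brought the large drops from compounds 1 and 2 to compound 3, while no measured step shows a recovery at greater length. Compound 4 is therefore expected to give 20% in this assay, within a range of 2% to 42%. The expected step is a number 16.4 percentage points lower from compound 3 to compound 4 (beyond the scatter).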

Compound 4, a percentage reported as inhibition, in the whole organism at one dose (the size of the read-out at that dose, not a potency): 39%
For compound 4 the middle estimate is 19 percentage points below the measured one, and the stated range covers the measured number.
By their numbers in this assay, from the lowest: compounds 3 and 4 (each within the scatter of the next); then compounds 1 and 2 (each within the scatter of the next).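

In this assay, adding propyl at this place, eight bonds along the chain from an amide-type nitrogen, gives a number 2.6 percentage points higher from compound 3 to compound 4 (within the scatter), so the large loss seen on reaching compound 3 does not deepen with this further lengthening. The shorter chains remain clearly ahead of this longest chain, with a number 36.2 percentage points lower from compound 2 to compound 4 (beyond the scatter) and a number 31.9 percentage points lower from compound 1 to compound 4 (beyond the scatter), so the two long-chain compounds sit together at a low level rather than on a continuing slope. Nothing available here gives a reason for this pattern.

Going by these compounds, it remains open at which chain length between those of compound 2 and compound 3 the loss sets in, and whether a still longer chain would stay at this level. On these data alone, the effect of a phenyl ring or a hydroxyl group in place of the plain chain is also open.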